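Replacing the Indole of Compound 3 with 4-Vinylphenyl

This account rests on a few compounds, and the source may have more. Where it says the series, first, only, none or still open, it means among the compounds named here.

Among the compounds with values here, in a functional assay on MCF7 cells (Homo sapiens) for inhibition, read by CCK-8 assay, with a stated time of 48 h (a lower number here means a stronger inhibitor, a higher number a weaker inhibitor), compound 3 `COc1cc(-c2ccnc3cc(-c4ccc5c(ccn5C)c4)nn23)cc(OC)c1OC` gives 3 nM, the lowest of the three numbers measured so far. Compound 1 `COc1cc(-c2ccnc3cc(-c4ccc(Cl)cc4)nn23)cc(OC)c1OC` gives 2320 nM, and compound 2 `Cn1ccc2cc(-c3cc4nccc(-c5ccc(F)cc5)n4n3)ccc21` gives 4580 nM.

The next compound, compound 4 `C=Cc1ccc(-c2cc3nccc(-c4cc(OC)c(OC)c(OC)c4)n3n2)cc1`, is made from compound 3 by putting 4-vinylphenyl in place of 1-methyl-1H-indol-5-yl on an aromatic carbon.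

Within the data shown here, one measured step bears directly on this change. It is the large step of a 770-fold lower number from compound 1 to compound 3 (2.89 log units; beyond the scatter), in which 1-methyl-1H-indol-5-yl replaced 4-chlorophenyl. Compound 4 gives up that same indole group and, like compound 1, carries a phenyl group with a single substituent. Compound 2 also carries 1-methyl-1H-indol-5-yl and still gives 4580 nM, so the group does not bring a low number in every compound here. Among the measured compounds shown here, no measured compound carries a vinyl group, so how far compound 4 falls back toward compound 1 remains uncertain.

A substantial rise beyond the scatter in this assay is therefore expected, though probably smaller than the full reverse of that step. The estimated change is a 33-fold higher number from compound 3 to compound 4 (1.52 log units; beyond the scatter). For compound 4 the expected value is 100 nM, with an estimated range of 8 nM to 1500 nM.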

Compound 4, half-maximal inhibitory concentration: 193 nM
Beside the measured number, compound 4's estimate is 1.9-fold (0.29 log units) below it; the range from low to high includes it.
By their numbers in this assay, from the lowest: compound 3; then compound 4; then compounds 1 and 2 (each within the scatter of the next).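

In this assay, the change brings a 64-fold higher number from compound 3 to compound 4 (1.81 log units; beyond the scatter), so at this position on the five-membered aromatic ring, 4-vinylphenyl does not take the place of 1-methyl-1H-indol-5-yl without a large rise in the number. The earlier compounds shown here compared the indole only with 4-chlorophenyl, and compound 4 now shows that the single substituent on the phenyl group also counts: vinyl in place of chloro gives a 12-fold lower number from compound 1 to compound 4 (1.08 log units; beyond the scatter) at the same position. A phenyl group with a single substituent can therefore reach a far lower number than compound 1 showed, although among these four compounds the indole of compound 3 still gives the lowest number.

The measurements give no explanation for either step, and nothing offered here accounts for the difference between the vinyl group, the chloro group and the indole. Going by these compounds, it remains open whether an amine or a longer chain such as propenyl in place of the vinyl group would bring the number closer to that of compound 3 or move it back toward that of compound 1.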